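Unbound fraction expected for compound 4

A few compounds are considered here, and "the series" means these few. Any claim that something is new, unique, unknown or untested is made for them only; others in the source may bear on it.

In an ADME assay on the whole organism (plasma, Homo sapiens) for protein binding, read by LC-MS, with a stated time of 24 h (on this read-out lower numbers stand for a smaller free fraction and higher numbers for a larger free fraction), compound 3 `Cc1noc(-c2ccc(O[C@H]3CCC[C@H](C(=O)O)C3)cc2)c1CNC(=O)OCc1ccccc1` gives 0.005, within the scatter of compound 2 `Cc1noc(-c2ccc(O[C@H]3CCC[C@H](C(=O)O)C3)cc2)c1CNC(=O)OCCC(C)(C)C` at 0.006 and of compound 1 `Cc1noc(-c2ccc(O[C@H]3CCC[C@H](C(=O)O)C3)cc2)c1COC(=O)N(C)CCC(C)C` at 0.003. Compound 4 `Cc1noc(-c2ccc(O[C@H]3CCC[C@H](C(=O)O)C3)cc2)c1COC(=O)N(C)C1CCCC1` differs from compound 3 as follows: a group of 10 heavy atoms (7 carbon, 1 nitrogen, 2 oxygen; one five-membered non-aromatic ring of carbon only) in place of a group of 11 heavy atoms (8 carbon, 1 nitrogen, 2 oxygen; one six-membered aromatic ring of carbon only), on a saturated chain carbon bound to an aromatic carbon. For the measured compounds named here, three measured steps bear on this change, all made at the same place or one atom further out, and all within the scatter: a 2.0-fold higher number from compound 1 to compound 2 (0.30 log units; within the scatter), a 1.7-fold higher number from compound 1 to compound 3 (0.22 log units; within the scatter) and a 1.2-fold lower number from compound 2 to compound 3 (0.08 log units; within the scatter). With steps of that size, no step beyond the scatter is expected in this assay. The expected step is a 1.3-fold lower number from compound 3 to compound 4 (0.10 log units; within the scatter), which stays inside the scatter. Compound 4 is estimated at 0.004, with an expected range of 0.002 to 0.008.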

Compound 4, unbound fraction: 0.004
The estimate for compound 4 equals the measured number at the digits printed; measured number inside the range.
By their numbers in this assay, from the lowest: compounds 1, 4, 3 and 2 (each within the scatter of the next).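

In this assay, cyclopentyl in place of isopentyl on the amide-type nitrogen stays within the scatter (a 1.3-fold higher number from compound 1 to compound 4 (0.12 log units; within the scatter)), so a saturated ring there reads like the open chain. The same holds against the groups with the aromatic ring (a 1.3-fold lower number from compound 3 to compound 4 (0.10 log units; within the scatter)) and the neopentyl end (a 1.5-fold lower number from compound 2 to compound 4 (0.18 log units; within the scatter)), which puts a third kind of end group in the same narrow band.

On these data alone, whether any group at this place can move the number beyond the scatter stays open, as does the effect of an amine or a carboxylic acid in this group. No measurement shown explains these steps.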